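Removing the Piperidine Methoxy While Keeping the Aromatic One

The source may report more compounds than this note shows. Statements on the series, on what has been measured and on what is new or still open speak of the compounds shown alone.

Of the compounds shown here, three have been measured in an assay on isolated protein for inhibition of NUAK family SNF1-like kinase 1 (Homo sapiens), read by ADP-Glo, with a stated time of 60 min, tested at 10 uM, in the presence of a further agent that is not named here; a lower number here means less inhibition, a higher number more inhibition at the concentration tested (going by the name of the read-out). Compound 1 `CCC(=O)Nc1cccc(Oc2nc(Nc3ccc(N4CCN(C)CC4)cc3Cl)ncc2Cl)c1` gives 71.5%, and compound 3 `CCC(=O)Nc1cccc(Oc2nc(Nc3ccc(N4CCC(OC)CC4)cc3)ncc2Cl)c1` gives 86.5%. Compound 2 `CCC(=O)Nc1cccc(Oc2nc(Nc3ccc(N4CCC(OC)CC4)cc3OC)ncc2Cl)c1` gives 5.08%, the lowest of the three numbers: the nearest is compound 1, and the furthest is compound 3. Among the compounds with values here, the only single-point step among them, a number 81.4 percentage points higher from compound 2 to compound 3 (beyond the scatter), removes a methoxy from an aromatic carbon and takes the inhibition in this assay from a low number to a much higher one.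

Compound 4 `CCC(=O)Nc1cccc(Oc2nc(Nc3ccc(N4CCCCC4)cc3OC)ncc2Cl)c1` differs from compound 2 at another site: hydrogen in place of methoxy on a saturated ring carbon. Here the aromatic methoxy stays in place, and the change is confined to the 4-methoxypiperidin-1-yl group, which becomes piperidin-1-yl. Within the data shown here, no measured step touches the saturated ring carbon, so the step from compound 2 to compound 3 bears on this change only indirectly, by showing that the aromatic methoxy of compound 2 goes with low inhibition, and that methoxy remains in compound 4.

On that basis the change in this assay is expected to be small, a number 9.9 percentage points higher from compound 2 to compound 4 (within the scatter), with no direction beyond the scatter assured. The estimate for compound 4 is 15%, expected to fall between 0% and 45%.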

Compound 4, a percentage reported as inhibition, at one concentration (the size of the read-out at that concentration, not a potency): 13.9%
The estimate for compound 4 lay 1.1 percentage points above the measured number, and the stated range covers the measured number.
By their numbers in this assay, from the lowest: compounds 2 and 4 (each within the scatter of the next); then compound 1; then compound 3.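

In this assay, within the data shown here, the step of a number 8.8 percentage points higher from compound 2 to compound 4 (within the scatter) gives the first direct reading at the saturated ring carbon, three ring bonds from the ring nitrogen. With the aromatic methoxy kept, changing 4-methoxypiperidin-1-yl to piperidin-1-yl produces no difference beyond the scatter, so among the single changes shown, only the step at the aromatic carbon, a number 81.4 percentage points higher from compound 2 to compound 3 (beyond the scatter), is large. No measurement is available that would explain why the methoxy on the saturated ring carbon makes so little difference here while the one on the aromatic carbon makes so much.

On these data alone, both compound 2 and compound 4 carry the aromatic methoxy, so it remains open whether the change from 4-methoxypiperidin-1-yl to piperidin-1-yl would also stay within the scatter on a compound without that methoxy, such as compound 3. As far as these compounds go, it is also open how this saturated ring carbon would respond to a group other than methoxy or hydrogen, such as a hydroxyl, an amine or a carboxylic acid, or to a longer chain.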